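This account rests on a few compounds, and the source may have more. Where it says the series, first, only, none or still open, it means among the compounds named here.

Measured so far:

Compound 1, `O=c1nc(N2CCN(NCC3CCCC3)CC2)sc2c([N+](=O)[O-])cc(C(F)(F)F)cc12`: in an ADME assay on Vero cells (Chlorocebus sabaeus) for cytotoxicity, read by MTT assay, with a stated time of 72 h (on this read-out lower numbers stand for higher toxicity in this test and higher numbers for lower toxicity in this test), compound 1 gives > 64 ug/mL, which is a limit of the assay rather than a number.
Compound 2, `O=c1nc(N2CCN(NCc3ccc(OC(F)(F)F)cc3)CC2)sc2c([N+](=O)[O-])cc(C(F)(F)F)cc12`: in this assay compound 2 gives > 64 ug/mL, again a limit.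
Compound 3, `CC(NN1CCN(c2nc(=O)c3cc(C(F)(F)F)cc([N+](=O)[O-])c3s2)CC1)c1ccc(OC(F)(F)F)cc1`: in this assay compound 3 gives > 64 ug/mL, also a limit.

Compound 3 therefore stands only at the limit of > 64 ug/mL in this assay, at which 3 of the 3 values shown sit; no number is known for it, and the same holds for the two compounds around it. Compound 4, `CC(c1ccc(OC(F)(F)F)cc1)N(C)N1CCN(c2nc(=O)c3cc(C(F)(F)F)cc([N+](=O)[O-])c3s2)CC1`, differs from compound 3 by methyl in place of hydrogen on an amine nitrogen. For the measured compounds named here, two measured steps touch the same part of the molecule: a step that the two limits leave unreadable from compound 1 to compound 2 and a step that the two limits leave unreadable from compound 2 to compound 3, the second being a methyl placed on a saturated chain carbon bound to an amine nitrogen and an aromatic carbon. Neither step can be read, because every value sits at the limit of > 64 ug/mL in this assay, at which 3 of the 3 values shown sit. Nothing in these three compounds points to a readable change in this assay from a single added methyl, so the expected step that the limit leaves unreadable from compound 3 to compound 4 is none beyond the scatter. Compound 4 is accordingly estimated at 80 ug/mL, within 40 ug/mL to 160 ug/mL, most likely reported again as a limit.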

Compound 4, half-maximal cytotoxic concentration: > 64 ug/mL
Compound 4 was reported as a limit (the forecaster's own chance of this, stated with the estimate: 80%); the middle value lies beyond the limit too.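

No new step can be read, because compound 3 and compound 4 both sit at a limit, so the methyl placed on the amine nitrogen has no measurable size: the limit of > 64 ug/mL in this assay, at which 4 of the 4 values shown sit. The compounds shown leave open whether this methyl, or any other change among them, shifts the result in this assay at all.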